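The source may hold more compounds than are shown below. What is called first, only, known or untested is meant among the compounds shown, and "the series" means these compounds.

Compounds measured so far in an ADME assay on microsomes from liver (Mus musculus) for metabolic stability, read by LC-MS, with NADPH named in the record, with a stated time of 60 min, tested at 1 uM, in the absence of a further agent; on this read-out higher numbers stand for a more stable compound and lower numbers for a less stable compound:
compound 1 `COc1ccc(-c2c(C)nc3c(N4CC[C@@H](NC(C)=O)C4)cc(C)nn23)cc1OC`: > 95%
compound 2 `COc1ccc(-c2c(C)nc3c(N4CC[C@@H](NC(C)=O)C4)cc(C)nn23)cc1F`: > 95%

Compound 1 stands at a limit of the assay, > 95%, and has no exact number. Compound 2 is likewise reported only as a limit, > 95%. Both measured compounds therefore sit at the same end of the scale: the limit of > 95% in this assay, at which 2 of the 2 values shown sit.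

Compound 3 `CCCCCC(=O)N[C@@H]1CCN(c2cc(C)nn3c(-c4ccc(OC)c(OC)c4)c(C)nc23)C1` differs from compound 1 in one place: butyl in place of hydrogen on a saturated chain carbon bound to a carbonyl carbon. This is butyl in place of hydrogen on a saturated chain carbon bound to a carbonyl carbon, which turns acetamido into (pentylcarbonyl)amino.

Among the compounds with values here, the only measured step, a step that the two limits leave unreadable from compound 1 to compound 2, is fluoro in place of methoxy on an aromatic carbon. Within the data shown here, it has no readable size and does not involve this chain, so no measured step gives a size for the new change. The expectation in this assay rests on the structural change alone and is set wide, with a downward direction. The expected step is a number at least 35 percentage points lower from compound 1 to compound 3 (beyond the scatter). For compound 3 the estimated value is 60%, with an expected range of 30% to 90%.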

Compound 3, percent of the compound remaining: > 95%
Compound 3: only a limit was reported (the forecaster's own chance of this, stated with the estimate: 15%); at least 35 percentage points between middle value and limit.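

In this assay, compound 3 is reported only as a limit, like compound 1, and no step between compound 1 and compound 3 can be read: the limit of > 95% in this assay, at which 3 of the 3 values shown sit.

The compounds shown leave open how far acetamido to (pentylcarbonyl)amino changes the percent remaining, and which change to the series, if any, would bring a value off this limit.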